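Cytotoxicity notes: methylation of a ring oxygen in compound 3

A few compounds are considered here, and "the series" means these few. Any claim that something is new, unique, unknown or untested is made for them only; others in the source may bear on it.

Measured compounds:
compound 1 `COc1ccc(OC)c(/C=N/NC(=O)Nc2ccc(Oc3ccnc(-c4nncn4CCN(C)C)c3)c(F)c2)c1` — "not determined" (no result reported)
compound 2 `CN(C)CCn1cnnc1-c1cc(Oc2ccc(NC(=O)N/N=C/c3cccc(Br)c3)cc2F)ccn1` — 4230 nM
compound 3 `CN(C)CCn1cnnc1-c1cc(Oc2ccc(NC(=O)N/N=C/c3ccc(O)c(O)c3)cc2F)ccn1` — "not determined" (no result reported)

Among the compounds with values here, in an ADME assay on WI-38 cells (Homo sapiens) for cytotoxicity, read by MTT assay, with a stated time of 72 h (on this read-out lower numbers stand for stronger inhibition and higher numbers for weaker inhibition), compound 2 gives 4230 nM and is the only member of the series with a number. Compound 3 stands without a single value in this assay, and one further compound also lacks one, so compound 3 cannot be placed against compound 2 on the numbers shown. Compound 4 `COc1cc(/C=N/NC(=O)Nc2ccc(Oc3ccnc(-c4nncn4CCN(C)C)c3)c(F)c2)ccc1O` differs from compound 3 by methyl in place of hydrogen on an oxygen on an aromatic ring. No step between measured compounds is available to size this change, and no direction beyond the usual scatter of this assay can be read from the shown values. Within the data shown here, the only anchor is the value of compound 2. Compound 4 is expected to give about 4500 nM, within a range from 1500 nM to 15000 nM.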

Compound 4, half-maximal inhibitory concentration: 5320 nM
For compound 4 the middle estimate is 1.2-fold (0.07 log units) below the measured one; low and high end bracket the measured number.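

Putting 4-hydroxy-3-methoxyphenyl in place of 3-bromophenyl on the carbon with a double bond to nitrogen gives, in this assay, a 1.3-fold higher number from compound 2 to compound 4 (0.10 log units; within the scatter) and does not tell the two groups apart. The step from hydroxy to methoxy itself cannot be read: compound 3 has no number. Nothing measured bears on why the two values lie so close.

From the compounds shown here alone, whether methyl in place of hydrogen on this oxygen moves the number at all stays open. Also open, going by these compounds, is the outcome with a carboxylic acid or an amine on this aromatic ring.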